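Compound 4 after three limits

A few compounds are considered here, and "the series" means these few. Any claim that something is new, unique, unknown or untested is made for them only; others in the source may bear on it.

Measured in a physicochemical assay for solubility, read by HPLC, with a stated time of 20 h, at pH 1; a lower number here means a less soluble compound, a higher number a more soluble compound:
- Compound 1 `NC(=O)C[C@H]1CC[C@H](c2ccc(C(=O)Nc3nnc(Cc4ccccc4)s3)cc2)CC1`: < 2000 nM, a limit
- Compound 2 `O=C(C[C@H]1CC[C@H](c2ccc(C(=O)Nc3nnc(Cc4ccccc4)s3)cc2)CC1)NCC(O)CO`: < 2000 nM, a limit
- Compound 3 `COCCNC(=O)C[C@H]1CC[C@H](c2ccc(C(=O)Nc3nnc(Cc4ccccc4)s3)cc2)CC1`: < 2000 nM, a limit

Compound 3 stands at < 2000 nM, which is a limit and not a number. Its two neighbours share that position, as the limit of < 2000 nM in this assay, at which 3 of the 3 values shown sit, shows.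

Compound 4 `CN(C)CCNC(=O)C[C@H]1CC[C@H](c2ccc(C(=O)Nc3nnc(Cc4ccccc4)s3)cc2)CC1` follows from compound 3 through one change: dimethylamino in place of methoxy on a saturated chain carbon, two bonds along the chain from an amide-type nitrogen. In words, dimethylamino takes the place of methoxy on a saturated chain carbon, two bonds along the chain from an amide-type nitrogen.

Within the data shown here, three measured steps bear on this change, and none offers a size. They are a step that the two limits leave unreadable from compound 1 to compound 3, a step that the two limits leave unreadable from compound 1 to compound 2 and a step that the two limits leave unreadable from compound 2 to compound 3. None of them places dimethylamino on the chain, so the size expected here is a judgement and not a reading from the data.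

An upward move in this assay is expected, with wide uncertainty, and the expected step is an at least 10-fold higher number from compound 3 to compound 4 (1.00 log units; beyond the scatter). For compound 4 the estimated value is 20000 nM, with an expected range from 2000 nM to 200000 nM.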

Compound 4, solubility: 6000 nM
The estimate for compound 4 lay 3.3-fold (0.52 log units) above the measured number; the range from low to high includes it.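

In this assay, compound 4 is the only one of the four shown to give a number rather than a limit, and dimethylamino in place of methoxy, on a saturated chain carbon two bonds along the chain from an amide-type nitrogen, yields the first readable step at this position (an at least 3.0-fold higher number from compound 3 to compound 4 (0.47 log units; beyond the scatter)). The 2-(dimethylamino)ethyl chain also stands clear of the amide hydrogen (an at least 3.0-fold higher number from compound 1 to compound 4 (0.47 log units; beyond the scatter)) and, one bond further in, of the 1,2-dihydroxyethyl group (an at least 3.0-fold higher number from compound 2 to compound 4 (0.47 log units; beyond the scatter)). The steps among compound 1, compound 2 and compound 3 cannot be read: (the limit of < 2000 nM in this assay, at which 3 of the 4 values shown sit).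

Going by these compounds, the full size of each new step stays open, as each one starts from a limit. Also open, on these data alone, is whether a primary amine, a carboxylic acid or a longer chain carrying dimethylamino would give a number in this assay.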